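From 4-methylphenyl to 4-chlorophenyl in a weak series

A few compounds are considered here, and "the series" means these few. Any claim that something is new, unique, unknown or untested is made for them only; others in the source may bear on it.

Measured compounds:
compound 1 (`CCCC1C(C(=O)OC)=C(C)NC(C)=C1C(=O)OC`): "not active" (no number reported)
compound 2 (`CCCCC1C(C(=O)OC)=C(C)NC(C)=C1C(=O)OC`): 500000 nM
compound 3 (`COC(=O)C1=C(C)NC(C)=C(C(=O)OC)C1c1ccc(C)cc1`): "not active" (no number reported)

In a functional assay on HT-29 cells (Homo sapiens) for cytotoxicity, read by MTT assay, with a stated time of 48 h (on this read-out lower numbers stand for stronger inhibition and higher numbers for weaker inhibition), compound 3 reads "not active" (no number reported) and so has no single number. Compound 1 is the one other entry of that kind. Only compound 2 gives a number, at 500000 nM in this small set.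

Compound 4 (`COC(=O)C1=C(C)NC(C)=C(C(=O)OC)C1c1ccc(Cl)cc1`) differs from compound 3 by chloro in place of methyl on an aromatic carbon The change lies on a six-membered aromatic ring of carbon only, para to a large group. Going by the values given here, no measured step shows this change, so the data give no direct size for it. The expected step in this assay is none beyond the scatter, with neither direction favoured, and compound 4 may again be reported without a number. Among the compounds with values here, this expectation rests on compound 3 at "not active" (no number reported) and compound 2 at 500000 nM as the only guides. In this assay compound 4 is estimated at 300000 nM (expected range 80000 nM to 1000000 nM) if a number is reported at all.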

Compound 4, half-maximal inhibitory concentration: "not active" (no number reported)
Compound 4: no number reported; no gap can be computed for the estimate.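

Compound 3 and compound 4 are both reported without a number, and no step can be read for 4-methylphenyl to 4-chlorophenyl. On these data alone, whether chloro in place of methyl shifts the read-out at all remains open. No evidence bears on this result.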